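This account rests on a few compounds, and the source may have more. Where it says the series, first, only, none or still open, it means among the compounds named here.

Compound 1, `Cn1nc(CCO)ccc1=O`, in a functional assay on aorta (Rattus norvegicus) (on this read-out higher numbers stand for weaker inhibition and lower numbers for stronger inhibition), gives > 100000 nM.
Compound 2, `Cn1nc(CCOCc2ccccc2)ccc1=O`, in this assay gives > 100000 nM.

Each of these values is a limit of the measurement, not a number. Compound 1 therefore stands at the limit of > 100000 nM in this assay, at which 2 of the 2 values shown sit, and nothing separates it from compound 2. Compound 3, `Cn1nc(CO)ccc1=O`, differs from compound 1 by hydroxy in place of hydroxymethyl on a saturated chain carbon bound to an aromatic carbon. Within the data shown here, no step between measured compounds is available to lean on. With both known values sitting at the limit, the expected step that the limit leaves unreadable from compound 1 to compound 3 is none beyond the scatter. Compound 3 is estimated at 150000 nM, in the range 50000 nM to 500000 nM, most likely again reported only as a limit.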

Compound 3, half-maximal inhibitory concentration: > 100000 nM
Compound 3 gave a limit, no number (the forecaster's own chance of this, stated with the estimate: 85%); the middle value does not contradict the limit.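

Among these compounds, compound 1 and compound 3 each give only a limit in this assay, and no step between them can be read. The compounds shown leave open how strongly any of them inhibits and whether the change of chain matters at all.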